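Adding a Methyl to the Anilide Ring of Compound 1

The compounds below may be only part of what the source reports. "The series", "measured", "known", "first", "only" and "open" are said of these compounds alone.

Measured compounds, with their results in a functional assay on A-375 cells (Homo sapiens) for antiproliferative activity, read by MTT assay, with a stated time of 48 h; on this read-out lower numbers stand for stronger inhibition and higher numbers for weaker inhibition:
- Compound 1 `CCCCCCc1nc(N)n(CC(=O)Nc2ccccc2)c1-c1ccccc1Br` gives 5700 nM
- Compound 2 `Nc1nc(Cc2ccccc2)c(-c2ccccc2Br)n1CC(=O)Nc1ccccc1` gives 5200 nM
- Compound 3 `CC(C)(C)c1ccc(Cc2nc(N)n(CC(=O)Nc3ccccc3)c2-c2ccccc2Br)cc1` gives 2800 nM

Compound 1 has the highest number of the three, meaning the weakest inhibition on this read-out. Its nearest neighbour is compound 2, a step of a 1.1-fold lower number from compound 1 to compound 2 (0.04 log units; within the scatter), which is within the scatter; the step of a 2.0-fold lower number from compound 1 to compound 3 (0.31 log units; beyond the scatter) is larger and just beyond it.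

Compound 4 `CCCCCCc1nc(N)n(CC(=O)Nc2ccc(C)cc2)c1-c1ccccc1Br` differs from compound 1 in one place: methyl in place of hydrogen on an aromatic carbon. For the measured compounds named here, none of the measured steps alters this ring; the steps from compound 1 to compounds 2 and 3 change the group on the saturated chain carbon, and a 1.9-fold lower number from compound 2 to compound 3 (0.27 log units; within the scatter) adds an alkyl group to an aromatic carbon of a different ring, within the scatter. Going by the values given here, with no direct precedent, the expected step of a 1.3-fold lower number from compound 1 to compound 4 (0.10 log units; within the scatter) is none beyond the scatter, with if anything a slightly lower number. Compound 4 is therefore estimated at 4500 nM, with a likely range from 1800 nM to 11000 nM.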

Compound 4, half-maximal inhibitory concentration: 5100 nM
Compound 4: the middle estimate sits 1.1-fold (0.05 log units) below what was measured; low and high end bracket the measured number.
By their numbers in this assay, from the lowest: compounds 3, 4, 2 and 1 (each within the scatter of the next, the first and the last beyond it).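

In this assay, turning the phenylcarbamoyl group into (4-methylphenyl)carbamoyl gives a 1.1-fold lower number from compound 1 to compound 4 (0.05 log units; within the scatter), so one added carbon at this spot, para to a large group, leaves the result within the usual scatter. For the compounds shown here, this is the first view of this ring, as the earlier steps changed only the group on the saturated chain carbon or a different ring, and it shows that this position accepts a small alkyl group with no measurable gain or loss of activity. Nothing measured here explains this outcome.

On these data alone, it remains open whether a carboxylic acid, an amine or a methoxy group at the same carbon would also leave the number within the scatter. As far as these compounds go, it is equally open whether the methyl would behave the same way on the anilide ring of compound 2 or compound 3.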